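Coumarin-Propargylamine Series: Benzyl Substituent Steps

A few compounds are considered here, and "the series" means these few. Any claim that something is new, unique, unknown or untested is made for them only; others in the source may bear on it.

Measured compounds:
compound 1 `C#CCN(CCCOc1ccc2ccc(=O)oc2c1)Cc1ccc(C)cc1` 116000 nM
compound 2 `C#CCN(CCCOc1ccc2ccc(=O)oc2c1)Cc1ccc(F)c(F)c1` 49200 nM
compound 3 `C#CCN(CCCOc1ccc2ccc(=O)oc2c1)Cc1ccccc1` 38600 nM

These values come from an ADME assay on isolated protein for inhibition of Amine oxidase [flavin-containing] A (Homo sapiens), read by fluorescence and Amplex Red, with stated times of 15 min and 20 min; a lower number here means a stronger inhibitor, a higher number a weaker inhibitor. Going by the values given here, compound 3 gives the lowest number of the three, but the nearest step, a 1.3-fold lower number from compound 2 to compound 3 (0.11 log units; within the scatter), lies within the scatter; only the step of a 3.0-fold lower number from compound 1 to compound 3 (0.48 log units; beyond the scatter) stands beyond the scatter, as does a 2.4-fold lower number from compound 1 to compound 2 (0.37 log units; beyond the scatter).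

Compound 4 `C#CCN(CCCOc1ccc2ccc(=O)oc2c1)Cc1cccc(OC)c1` differs from compound 3 by methoxy in place of hydrogen on an aromatic carbon. Among the compounds with values here, no measured step concerns a methoxy group; the only ring-substituent steps are those of compound 1 and compound 2 toward compound 3, and those were modest or within the scatter. In this assay compound 4 is therefore expected to sit close to compound 3, with a step of a 1.0-fold higher number from compound 3 to compound 4 (0.02 log units; within the scatter) expected to lie within the scatter. The estimate for compound 4 is 40000 nM, expected between 15000 nM and 110000 nM.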

Compound 4, half-maximal inhibitory concentration: 22700 nM
For compound 4 the middle estimate is 1.8-fold (0.25 log units) above the measured one; measured number inside the range.
By their numbers in this assay, from the lowest: compounds 4, 3 and 2 (each within the scatter of the next, the first and the last beyond it); then compound 1.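

Methoxy as the 3-methoxyphenyl group is accommodated on this ring in this assay, with a 1.7-fold lower number from compound 3 to compound 4 (0.23 log units; within the scatter) as the step, so compound 4 cannot be told apart from compound 3. Going by these compounds alone, the group does separate compound 4 from both other substituted compounds, through a 2.2-fold lower number from compound 2 to compound 4 (0.34 log units; beyond the scatter) and through a 5.1-fold lower number from compound 1 to compound 4 (0.71 log units; beyond the scatter) as the widest step so far. No measurement shown offers a reason for these steps.

Open, going by these compounds, is whether a hydroxy or an amino group on this ring would step beyond the scatter from compound 3. Also open, on these data alone, is how a longer chain between the core and the amine nitrogen would read.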